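A few compounds are considered here, and "the series" means these few. Any claim that something is new, unique, unknown or untested is made for them only; others in the source may bear on it.

In a functional assay on HEK293 cells (Homo sapiens) for cytotoxicity (on this read-out lower numbers stand for higher toxicity in this test and higher numbers for lower toxicity in this test), compound 1 (`COc1ccc([C@H]2CC(=O)N(c3ccccc3)C2)cc1OC1CCCC1`) reads as a limit of the assay (> 10000 nM). Compound 2 (`COc1ccc([C@H]2CC(=O)N(c3cccc(C#N)c3)C2)cc1OC1CCCC1`) also reads as a limit (> 10000 nM). Compound 3 (`COc1ccc([C@H]2CC(=O)N(c3cccc(NS(=O)(=O)c4ccccc4Cl)c3)C2)cc1OC1CCCC1`) reads as a limit too (> 10000 nM), and so stands at the limit of > 10000 nM in this assay, at which 3 of the 3 values shown sit, with no number of its own.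

Compound 4 (`COc1ccc([C@H]2CC(=O)N(c3cccc(NS(=O)(=O)c4cccc(F)c4)c3)C2)cc1OC1CCCC1`) carries a single change, 3-fluorophenyl in place of 2-chlorophenyl on a sulfonyl sulfur. The measured steps that bear on it are a step that the two limits leave unreadable from compound 1 to compound 3 and a step that the two limits leave unreadable from compound 2 to compound 3, along with a step that the two limits leave unreadable from compound 1 to compound 2, and none offers a size to carry over. No step beyond the scatter is therefore expected in this assay, and the expected step is a step that the limit leaves unreadable from compound 3 to compound 4 on this read-out. Compound 4 is estimated at 15000 nM with an expected range of 10000 nM to 40000 nM in this series.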

Compound 4, half-maximal cytotoxic concentration: > 10000 nM
Compound 4: no number, only a limit (the forecaster's own chance of this, stated with the estimate: 90%); the middle value is on the limit's open side.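

In this assay compound 4 reads as a limit, > 10000 nM; its steps from compound 1, compound 2 and compound 3 cannot be read. Whether the sulfonyl aryl change affects this read-out stays open, with every value shown at: the limit of > 10000 nM in this assay, at which 4 of the 4 values shown sit.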